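The source may report more compounds than this note shows. Statements on the series, on what has been measured and on what is new or still open speak of the compounds shown alone.

In a functional assay on HCT-8 cells (Homo sapiens) for antiproliferative activity, read by MTT assay, with a stated time of 48 h (a higher number here means a weaker inhibitor, a lower number a stronger inhibitor), compound 1 `CNCC(=O)Nc1cc(OC)ccc1C(=O)c1cc(OC)c(OC)c(OC)c1` gives 780 nM. Compound 2 `CCNCC(=O)Nc1cc(OC)ccc1C(=O)c1cc(OC)c(OC)c(OC)c1` differs from it by one change, (methyl in place of hydrogen on a saturated chain carbon bound to an amine nitrogen), and in this assay compound 2 gives 1560 nM; the step of a 2.0-fold higher number from compound 1 to compound 2 (0.30 log units; within the scatter) is small. Compound 3 `C=C(c1cc(OC)c(OC)c(OC)c1)c1ccc(OC)cc1NC(=O)CNC` is built on a different core; the difference between the two cores is not broken down here. In this assay compound 3 gives 190 nM, the lowest number of the three, and its gaps to compound 1 and compound 2 both lie beyond the scatter.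

Compound 4 `C=C(c1cc(OC)c(OC)c(OC)c1)c1ccc(OC)cc1NC(=O)CNCC` is the unmeasured partner of compound 3, made by methyl in place of hydrogen on a saturated chain carbon bound to an amine nitrogen. This is the same change as from compound 1 to compound 2, and among the compounds shown it occurs twice in all. The expected step of a 1.8-fold higher number from compound 3 to compound 4 (0.27 log units; within the scatter) rests on that single earlier pair, because the step of a 2.0-fold higher number from compound 1 to compound 2 (0.30 log units; within the scatter) stayed within the scatter. Compound 4 is therefore expected to give about 350 nM, most likely between 180 nM and 750 nM.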

Compound 4, half-maximal inhibitory concentration: 590 nM
Estimate against measurement, compound 4: 1.7-fold (0.23 log units) below, within the range that was stated.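

In this assay, replacing methylamino with ethylamino on the core of compound 3 gives a 3.1-fold higher number from compound 3 to compound 4 (0.49 log units; beyond the scatter). This step lies beyond the scatter and the earlier one on the core of compound 1 does not, yet the two steps cannot be told apart from each other: the same change on two cores in this assay, a 2.0-fold higher number (0.30 log units; within the scatter) from compound 1 to compound 2 and a 3.1-fold higher number (0.49 log units; beyond the scatter) from compound 3 to compound 4, 1.6-fold (0.19 log units) apart, within the scatter of two such steps. The change therefore carried over from one core to the other with no detectable difference in size, but two pairs of compounds in a single cell assay make no general rule for this series, and they do not show why the number moves.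

The compounds shown leave open how the ethylamino result compares with an unsubstituted amino group, a dimethylamino group or a longer chain such as propylamino on either core. From the compounds shown here alone, it also remains open whether the two cores would still match for these other amines, or in other cell lines.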